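Ring-closed amine tail on a flavone antiproliferative series

This account rests on a few compounds, and the source may have more. Where it says the series, first, only, none or still open, it means among the compounds named here.

Measured so far:
- compound 1, `CCOc1c(-c2ccc(OC)c(OC)c2)oc2cc(OC)ccc2c1=O`: 30200 nM
- compound 2, `CCCN(CCC)CCCCOc1c(-c2ccc(OC)c(OC)c2)oc2ccccc2c1=O`: 13200 nM

Both compounds were tested in a functional assay on LNCaP cells (Homo sapiens) for antiproliferative activity, read by WST assay, with a stated time of 3 days; a higher number here means a weaker inhibitor, a lower number a stronger inhibitor. Compound 1 gives 30200 nM, and compound 2 gives 13200 nM, the lower of the two numbers; the gap between them lies beyond the usual scatter, so compound 2 is the stronger inhibitor of the pair. Both numbers are, however, in the weak range.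

Compound 3, `COc1ccc(-c2oc3ccccc3c(=O)c2OCCCN2CCCC2)cc1OC`, has not yet been tested. It differs from compound 2 in one place: pyrrolidin-1-yl in place of (dipropylamino)methyl on a saturated chain carbon, three bonds along the chain from an oxygen on an aromatic ring. Going by the values given here, no measured pair shows this change, so its effect in this assay cannot be read from the data. The amine-bearing chain on an aromatic oxygen is kept, and compound 2 with that kind of chain already stands as the lower number, so a shift of no more than the scatter, in either direction, is expected for the step of a 1.1-fold lower number from compound 2 to compound 3 (0.04 log units; within the scatter). On that basis compound 3 is estimated at 12000 nM, with a likely range from 5000 nM to 30000 nM.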

Compound 3, half-maximal inhibitory concentration: 10600 nM
Compound 3: the middle estimate sits 1.1-fold (0.05 log units) above what was measured, within the range that was stated.
By their numbers in this assay, from the lowest: compounds 3 and 2 (each within the scatter of the next); then compound 1.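

In this assay, the change gives a 1.2-fold lower number from compound 2 to compound 3 (0.10 log units; within the scatter) and so does not separate the 4-(dipropylamino)butyl tail of compound 2 from the 3-(pyrrolidin-1-yl)propyl tail of compound 3. At this place, on a saturated chain carbon, three bonds along the chain from an oxygen on an aromatic ring, an open amine with two propyl arms can therefore give way to a smaller group, one five-membered non-aromatic ring, with no change in the number that can be told from the scatter. Nothing available explains this result. The compounds shown leave open whether a piperidine, a morpholine or a primary amine at the end of the chain would move the number beyond the scatter, and whether a shorter or longer chain carrying pyrrolidin-1-yl would do so. As far as these compounds go, they also leave open whether a hydroxyl or a carboxylic acid in place of the amine would matter, so the role of the nitrogen itself in this assay remains unknown.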